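Acrylamide tail variation on a shared anilino core

A few compounds are considered here, and "the series" means these few. Any claim that something is new, unique, unknown or untested is made for them only; others in the source may bear on it.

Measured so far:
compound 1, `C=C(Cl)C(=O)Nc1cc(Nc2nc(C)cc(-c3cn(C)c4ccccc34)n2)c(OC)cc1N(C)CCN(C)C`, 2230 nM
compound 2, `CC/C=C\C(=O)Nc1cc(Nc2nc(C)cc(-c3cn(C)c4ccccc34)n2)c(OC)cc1N(C)CCN(C)C`, 1990 nM

Both compounds were run in a functional assay on NCI-H1975 cells (Homo sapiens) for antiproliferative activity, read by MTT assay, with a stated time of 72 h; a higher number here means a weaker inhibitor, a lower number a stronger inhibitor. Compound 1 gives 2230 nM and compound 2 gives 1990 nM; the step of a 1.1-fold lower number from compound 1 to compound 2 (0.05 log units; within the scatter) swaps but-1-en-1-yl for 1-chloroethenyl on the carbonyl carbon. Compound 2 therefore does not stand apart from compound 1 on these numbers; the two sit within the scatter of each other.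

Compound 3, `COc1cc(N(C)CCN(C)C)c(NC(=O)/C=C\C(C)C)cc1Nc1nc(C)cc(-c2cn(C)c3ccccc23)n1`, is not yet measured. Relative to compound 2 the change is methyl in place of hydrogen on a saturated chain carbon bound to a double-bonded chain carbon and a saturated chain carbon, read one bond further out as but-1-en-1-yl to 3-methylbut-1-en-1-yl on the carbonyl. Among the measured compounds shown here, the only step known, a 1.1-fold lower number from compound 1 to compound 2 (0.05 log units; within the scatter), also alters the tail on that carbonyl and stayed within the scatter, so no measured step points to a shift in either direction. The expected step of a 1.1-fold higher number from compound 2 to compound 3 (0.04 log units; within the scatter) is accordingly small, with no direction favoured beyond the scatter. Compound 3 is estimated at 2200 nM, with a range from 900 nM to 5500 nM.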

Compound 3, half-maximal inhibitory concentration: 1230 nM
The estimate for compound 3 lay 1.8-fold (0.25 log units) above the measured number, within the range that was stated.
By their numbers in this assay, from the lowest: compounds 3, 2 and 1 (each within the scatter of the next).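

Working notes on the tail at the carbonyl: in this assay, extending the branching at the saturated chain carbon, from ethyl to isopropyl as read one bond further out, gives a 1.6-fold lower number from compound 2 to compound 3 (0.21 log units; within the scatter) and stays within the scatter, so this methyl in place of hydrogen produces no resolved shift in either direction. The wider comparison on the same carbonyl gives a 1.8-fold lower number from compound 1 to compound 3 (0.26 log units; within the scatter) and also stays within the scatter, which means that 1-chloroethenyl, but-1-en-1-yl and 3-methylbut-1-en-1-yl cannot be ranked against one another on these numbers, and all three steps now available at this carbonyl lie inside the scatter. No supporting information bears on this result.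

Still open, from the compounds shown here alone, is whether any tail on this carbonyl can move the number beyond the scatter, for example a tail ending in a dimethylamine, one carrying a carboxylic acid, or a longer chain than 3-methylbut-1-en-1-yl. Also open is whether the same methyl in place of hydrogen would stay within the scatter on a tail of a different length, since only one such pair is shown.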